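Swapping a bromophenyl group for a fluorophenyl group

The compounds below may be only part of what the source reports. "The series", "measured", "known", "first", "only" and "open" are said of these compounds alone.

Compound 1 (`COc1cc2oc(-c3cccc(NC(=O)c4cccc(Br)c4)c3)cc(=O)c2c(OC)c1OC`): 10900 nM
Compound 2 (`COc1cc2oc(-c3cccc(NC(=O)c4ccccc4Br)c3)cc(=O)c2c(OC)c1OC`): 23100 nM

Both values come from a functional assay on HepG2 cells (Homo sapiens) for inhibition, read by MTT assay (on this read-out higher numbers stand for weaker inhibition of growth and lower numbers for stronger inhibition of growth), on compounds that share one core. Compound 2 at 23100 nM holds the higher of the two numbers, so it is the weaker growth inhibitor of this pair. Next comes compound 3 (`COc1cc2oc(-c3cccc(NC(=O)c4ccc(F)cc4)c3)cc(=O)c2c(OC)c1OC`) with 4-fluorophenyl in place of 2-bromophenyl on a carbonyl carbon, and the full count of that change is 4-fluorophenyl in place of 2-bromophenyl on a carbonyl carbon in detail.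

Within the data shown here, only one measured step bears on this, since it also changes the group on that carbonyl carbon. It is a 2.1-fold higher number from compound 1 to compound 2 (0.33 log units; beyond the scatter) for 2-bromophenyl in place of 3-bromophenyl, a modest change. Among the measured compounds shown here, no measured compound carries the 4-fluorophenyl group, so this evidence is thin. With compound 2 at the higher end, a step of similar or smaller size toward a lower number is expected in this assay and it may not clear the usual scatter. The expected change is a 1.7-fold lower number from compound 2 to compound 3 (0.22 log units; within the scatter) on this estimate. For compound 3 the estimated value is 14000 nM with an expected range from 6000 nM to 32000 nM in this test.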

Compound 3, concentration for 50% growth inhibition: 47200 nM
Compound 3: middle estimate off by 3.4-fold (0.53 log units), on the low side; the whole stated range lies below it.
By their numbers in this assay, from the lowest: compound 1; then compound 2; then compound 3.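

In this assay, this position on the carbonyl carbon responds more strongly than the two bromophenyl compounds alone showed: the 4-fluorophenyl group gives a 2.0-fold higher number from compound 2 to compound 3 (0.31 log units; beyond the scatter) and a 4.3-fold higher number from compound 1 to compound 3 (0.64 log units; beyond the scatter), which makes compound 3 the weakest growth inhibitor of the three. Among these compounds, this change swaps the halogen and also moves it around the ring, so the single step cannot show which of the two alterations drives the rise in the number. Nothing in the available data explains the difference between these groups.

From the compounds shown here alone, what remains open is whether the rise follows from the fluorine itself or from its place on the ring, a question that a 4-bromophenyl or a 3-fluorophenyl group on the same carbonyl carbon could help to settle. Also open, going by these compounds, is how a plain phenyl group, or a phenyl ring carrying an amine or a carboxylic acid, would read at this position.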